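Swapping the aryl on the triazole: from compound 3 to compound 4

This account rests on a few compounds, and the source may have more. Where it says the series, first, only, none or still open, it means among the compounds named here.

Measured so far:
Compound 1 `Cc1ccccc1-n1nncc1CN1C(=O)C2(C(C#N)=C(N)Oc3c(N)cc4nc5ccccc5nc4c32)c2ccccc21` in a functional assay on HepG2 cells (Homo sapiens) for antiproliferative activity, read by MTT assay, with a stated time of 48 h (on this read-out higher numbers stand for weaker inhibition and lower numbers for stronger inhibition), gives > 50000 nM, a limit of the assay rather than a number.
Compound 2 `N#CC1=C(N)Oc2c(N)cc3nc4ccccc4nc3c2C12C(=O)N(Cc1cnnn1-c1ccccc1Br)c1ccccc12` in this assay gives 38000 nM.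
Compound 3 `CCc1cccc(C)c1-n1nncc1CN1C(=O)C2(C(C#N)=C(N)Oc3c(N)cc4nc5ccccc5nc4c32)c2ccccc21` in this assay gives > 50000 nM, again a limit and not a number.

All three share one core and differ only in the aryl group on the triazole nitrogen. Compound 3 therefore stands at the assay limit, as does compound 1, a point summed up by the limit of > 50000 nM in this assay, at which 2 of the 3 values shown sit. The change to compound 4 `Cc1ccc(Cl)cc1-n1nncc1CN1C(=O)C2(C(C#N)=C(N)Oc3c(N)cc4nc5ccccc5nc4c32)c2ccccc21` is 5-chloro-2-methylphenyl in place of 2-ethyl-6-methylphenyl on an aromatic nitrogen. Among the compounds with values here, the steps that bear on it are small or unreadable: an at least 1.3-fold lower number from compound 1 to compound 2 (0.11 log units; that floor lies within the scatter), a step that the two limits leave unreadable from compound 1 to compound 3, and an at least 1.3-fold higher number from compound 2 to compound 3 (0.11 log units; that floor lies within the scatter). None of them rises beyond the scatter, and two of the three values are limits. For compound 4 the step of an at least 1.1-fold lower number from compound 3 to compound 4 (0.04 log units; that floor lies within the scatter) is expected to be no larger than the scatter in this assay. Compound 4 is thus estimated at 45000 nM, within 20000 nM to 100000 nM, with a real chance that only a limit is reported.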

Compound 4, half-maximal inhibitory concentration: 17300 nM
Compound 4: the middle estimate sits 2.6-fold (0.42 log units) above what was measured; the whole stated range lies above it.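

Adding a chloro to the aryl group on the aromatic nitrogen is the first change in this series to move the read-out clearly beyond the scatter in this assay, giving an at least 2.8-fold lower number from compound 1 to compound 4 (0.46 log units; beyond the scatter). The 5-chloro-2-methylphenyl group also stands ahead of the two other aryl groups, with a 2.2-fold lower number from compound 2 to compound 4 (0.34 log units; beyond the scatter) against 2-bromophenyl and an at least 2.8-fold lower number from compound 3 to compound 4 (0.46 log units; beyond the scatter) against 2-ethyl-6-methylphenyl, making compound 4 the strongest of the four. Two of these steps are only floors, set by a limit of the assay and not by a number: the limit of > 50000 nM in this assay, at which 2 of the 4 values shown sit.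

The compounds shown do not tell whether chloro itself matters, or whether a fluoro, a methoxy or an amine in its place would read the same. They also leave open how a carboxylic acid or a longer chain on this aryl ring would read.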